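From Methoxy to Hydroxy in a Small Compound Series

The source may report more compounds than this note shows. Statements on the series, on what has been measured and on what is new or still open speak of the compounds shown alone.

Compound 1 `COc1ccc(/C=C/C2(C)C=CC(=O)O2)c(OC)c1`: 53600 nM
Compound 2 `COc1ccc(/C=C/C2(C)C=CC(=O)O2)cc1OC`: 838000 nM
Compound 3 `COc1ccc(/C=C/C2(C)C=CC(=O)O2)c(OC)c1OC`: 217000 nM

These three values come from a functional assay on HaCaT cells (Homo sapiens) for inhibition, read by sulforhodamine B assay, with a stated time of 48 h; a higher number here means a weaker inhibitor of growth, a lower number a stronger inhibitor of growth. Compound 3 holds the middle place, with compound 1 giving a lower number and compound 2 a higher one.

The next compound, compound 4 `COc1c(O)ccc(/C=C/C2(C)C=CC(=O)O2)c1OC`, keeps the shared core and differs from compound 3 at one group: hydrogen in place of methyl on an oxygen on an aromatic ring. This places hydrogen in place of methyl on an oxygen on an aromatic ring, turning a methoxy into a hydroxy.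

For the measured compounds named here, no measured pair shows this exact change, so the evidence is indirect. The nearest guide is a pair of steps that each put methoxy in place of hydrogen on an aromatic carbon. One is a 4.0-fold higher number from compound 1 to compound 3 (0.61 log units; beyond the scatter), and the other is a 3.9-fold lower number from compound 2 to compound 3 (0.59 log units; beyond the scatter). Both are modest and beyond the scatter, but they run in opposite directions. They therefore give no direction for compound 4, and they suggest that a single change on this ring may shift the number only modestly. The expected step stays small and may well lie within the scatter: a 1.1-fold lower number from compound 3 to compound 4 (0.04 log units; within the scatter). Compound 4 is expected at about 200000 nM, with an estimated range from 60000 nM to 600000 nM.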

Compound 4, concentration for total growth inhibition: 64400 nM
Compound 4: the middle estimate sits 3.1-fold (0.49 log units) above what was measured; the range from low to high includes it.
By their numbers in this assay, from the lowest: compounds 1 and 4 (each within the scatter of the next); then compound 3; then compound 2.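

In this assay, putting hydrogen in place of methyl on an oxygen on an aromatic ring gives a 3.4-fold lower number from compound 3 to compound 4 (0.53 log units; beyond the scatter), so this methoxy to hydroxy change moves the compound towards stronger inhibition of growth. The earlier steps shown here only added a methoxy on an aromatic carbon and pointed in opposite directions, whereas this step shows that removing a single methyl carbon from an existing methoxy, with the rest of the structure unchanged, can also shift the number by a modest but real amount. Nothing measured here explains the direction or size of this shift.

The compounds shown leave open whether the same change at either of the other ring methoxy groups would move the number in the same direction, since this is a single pair and the effect of a group on this ring has already been seen to depend on the compound that carries it. They also leave open how the number would respond if this oxygen carried a longer chain such as ethoxy, or if an amine or a carboxylic acid stood in place of the hydroxy.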